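The compounds below may be only part of what the source reports. "The series", "measured", "known", "first", "only" and "open" are said of these compounds alone.

The shared core carries a hydrazone arm whose terminal aryl group is varied, and the read-out throughout is a functional assay on BGC-823 cells (Homo sapiens) for cytotoxicity, read by MTT assay, with a stated time of 48 h; on this read-out higher numbers stand for weaker inhibition and lower numbers for stronger inhibition. Compound 1, `O=C(CSc1nnc(-c2ccncc2)o1)N/N=C/c1ccc(F)cc1`, gives 17800 nM in this assay. Among the compounds with values here, compound 2, `O=C(CSc1nnc(-c2ccncc2)o1)N/N=C/c1ccccc1[N+](=O)[O-]`, gives 41600 nM in this assay; of the two compounds measured so far it stands at the highest number, that is the weaker inhibition, and the only measured step linking the pair is a 2.3-fold higher number from compound 1 to compound 2 (0.37 log units; beyond the scatter). Compound 3, `O=C(CSc1nnc(-c2ccncc2)o1)N/N=C/c1cccs1`, is not yet measured in this assay. The change from compound 2 to compound 3 is thiophen-2-yl in place of 2-nitrophenyl on a carbon with a double bond to nitrogen. Within the data shown here, the single measured step that bears on it is the exchange of one aryl group for another at the same place, and it was modest, only just beyond the scatter. Because a 2.3-fold higher number from compound 1 to compound 2 (0.37 log units; beyond the scatter) was a modest move, a step of similar modest size is expected here, toward a lower number and back toward the value of compound 1. For compound 3 the expected step is a 2.1-fold lower number from compound 2 to compound 3 (0.32 log units; beyond the scatter). Compound 3 is therefore estimated to give 20000 nM in this assay, with a range from 8000 nM to 60000 nM.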

Compound 3, half-maximal inhibitory concentration: 26700 nM
The estimate for compound 3 lay 1.3-fold (0.13 log units) below the measured number; measured number inside the range.
By their numbers in this assay, from the lowest: compounds 1, 3 and 2 (each within the scatter of the next, the first and the last beyond it).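

In this assay, putting thiophen-2-yl in place of 2-nitrophenyl swaps a six-membered carbon ring for a five-membered ring holding sulfur and gives a 1.6-fold lower number from compound 2 to compound 3 (0.19 log units; within the scatter), while the same group in place of 4-fluorophenyl gives a 1.5-fold higher number from compound 1 to compound 3 (0.18 log units; within the scatter). Within the data shown here, the earlier pair showed only that two substituted six-membered rings can differ here, with a 2.3-fold higher number from compound 1 to compound 2 (0.37 log units; beyond the scatter), whereas compound 3 shows that a smaller ring with a hetero atom can sit on this carbon with a double bond to nitrogen and stay within the scatter of both six-membered examples, so it cannot be ranked against either one. No measurement at hand explains these numbers.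

On these data alone, all three groups at this place are aromatic rings, so it remains open whether a non-aromatic group, such as a longer alkyl chain, an amine or a carboxylic acid, would give a number of similar size. As far as these compounds go, it also remains open whether thiophen-3-yl, or a thiophene ring bearing a chlorine atom or a methyl group, would separate from compound 3 by more than the scatter.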